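The source may report more compounds than this note shows. Statements on the series, on what has been measured and on what is new or still open speak of the compounds shown alone.

In an ADME assay on BaF3 cells (Mus musculus) for cytotoxicity, read by MTT assay, with a stated time of 48 h (a higher number here means a weaker inhibitor of growth, a lower number a stronger inhibitor of growth), compound 1 (`CC(C)n1nc(-c2cc(-c3ccccc3)on2)c2c(N)ncnc21`) gives > 10000 nM, which is a limit. Compound 2 (`CC(C)c1cc(-c2nn(C(C)C)c3ncnc(N)c23)no1`) gives > 10000 nM, also a limit and not a number. Going by the values given here, the series so far stands at the limit of > 10000 nM in this assay, at which 2 of the 2 values shown sit. Compound 3 (`CCc1cc(-c2nn(C(C)C)c3ncnc(N)c23)no1`) differs from compound 2 by hydrogen in place of methyl on a saturated chain carbon bound to an aromatic carbon and a saturated chain carbon, isopropyl to ethyl. Among the compounds with values here, the only measured step bearing on this is a step that the two limits leave unreadable from compound 1 to compound 2, so no measured size carries over. The expected step in this assay is a number no higher from compound 2 to compound 3 (the limit leaves the size open), with nothing expected beyond the scatter. For compound 3 the estimate is 10000 nM, with an expected range of 5000 nM to 20000 nM.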

Compound 3, concentration for 50% growth inhibition: > 10000 nM
Compound 3: no number, only a limit; the forecaster's own chance of this, stated with the estimate: 85%; the middle value lies on the limit itself.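

No step among compound 1, compound 2 and compound 3 can be read, as all three values are limits and not numbers: the limit of > 10000 nM in this assay, at which 3 of the 3 values shown sit.

The compounds shown leave open whether phenyl, isopropyl and ethyl on the aromatic carbon differ at all in this assay.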